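The source may report more compounds than this note shows. Statements on the series, on what has been measured and on what is new or still open speak of the compounds shown alone.

Measured so far in a functional assay on PC-3 cells (Homo sapiens) for antiproliferative activity, read by MTT assay, with a stated time of 48 h; a higher number here means a weaker inhibitor, a lower number a stronger inhibitor:
Compound 1, `COc1cc(N(Cc2ccccc2)C(=O)CSc2nc3ccccc3s2)cc(OC)c1OC`, gives 54100 nM.
Compound 2, `COc1cc(N(Cc2ccc(F)cc2)C(=O)CSc2nc3ccccc3s2)cc(OC)c1OC`, gives 50800 nM.
Compound 3, `COc1cc(N(Cc2ccc(Br)cc2)C(=O)CSc2nc3ccccc3s2)cc(OC)c1OC`, reaches only a limit of the assay, > 80000 nM.

Compound 3 stands at the weak end of the numbers shown: its value in this assay is a limit and not a number, and the limit of > 80000 nM in this assay, at which 1 of the 3 values shown sits, marks where it sits. The measured steps are small. From compound 1 to compound 2 the change was a 1.1-fold lower number from compound 1 to compound 2 (0.03 log units; within the scatter). Toward compound 3, an at least 1.4-fold higher number from compound 1 to compound 3 (0.16 log units; that floor lies within the scatter) and an at least 1.5-fold higher number from compound 2 to compound 3 (0.19 log units; that floor lies within the scatter) are floors that also lie within the scatter, so the three measured compounds do not separate from one another beyond the scatter.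

Compound 4, `COc1ccc(CN(C(=O)CSc2nc3ccccc3s2)c2cc(OC)c(OC)c(OC)c2)cc1OC`, differs from compound 3 by 3,4-dimethoxyphenyl in place of 4-bromophenyl on a saturated chain carbon bound to an amide-type nitrogen. Within the data shown here, none of the measured steps bears directly on this change: they exchange hydrogen, fluoro and bromo on the benzyl group, and each stayed within the scatter. There is therefore no measured ground to expect a step beyond the scatter in this assay in either direction. Compound 4 is accordingly estimated at 60000 nM, with a range from 25000 nM to 150000 nM. This estimate implies a step of an at least 1.3-fold lower number from compound 3 to compound 4 (0.12 log units; that floor lies within the scatter), which is expected to remain within the scatter of the measurements.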

Compound 4, half-maximal inhibitory concentration: > 80000 nM
Compound 4: a limit, no number (the forecaster's own chance of this, stated with the estimate: 45%); middle value at least 1.3-fold (0.12 log units) away from the limit.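

In this assay compound 4 reaches only a limit of the assay, > 80000 nM. Set against the two measured compounds on this saturated chain carbon bound to an amide-type nitrogen, the result gives an at least 1.5-fold higher number from compound 2 to compound 4 (0.19 log units; that floor lies within the scatter) and an at least 1.4-fold higher number from compound 1 to compound 4 (0.16 log units; that floor lies within the scatter), so even an exchange of the whole aryl group for 3,4-dimethoxyphenyl, not only of hydrogen, fluoro or bromo on it, yields only floors that lie within the scatter, while the step between the two limits cannot be read. What the earlier compounds did not show is that the limit is no longer tied to 4-bromophenyl alone, for a group with two hydrogen-bond acceptors and no bromine now sits there as well: the limit of > 80000 nM in this assay, at which 2 of the 4 values shown sit.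

Going by these compounds, how far compound 3 and compound 4 lie from each other stays open, as does whether either differs from compound 1 beyond the scatter. Also open, on these data alone, is whether an amine or a carboxylic acid on the phenyl ring, or a longer chain at this place, would give a number clearly apart from that of compound 1.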